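Swapping iodo for methyl on an aminochalcone core

The compounds below may be only part of what the source reports. "The series", "measured", "known", "first", "only" and "open" are said of these compounds alone.

Three chalcone-type compounds have been tested in an ADME assay on CCRF-CEM cells (Homo sapiens) for antiproliferative activity, with a stated time of 48 h; on this read-out higher numbers stand for weaker inhibition and lower numbers for stronger inhibition. Compound 1 `C=C(Br)C(=O)Nc1ccc(/C=C/C(=O)c2ccc(I)cc2)cc1` gives 4000 nM in this assay, compound 2 `C=C(Br)C(=O)Nc1ccc(/C=C/C(=O)c2ccc(C)cc2)cc1` gives 1800 nM, and compound 3 `Nc1ccc(/C=C/C(=O)c2ccc(I)cc2)cc1` gives 16000 nM, the highest of the three numbers. Compound 3 and compound 1 differ in their cores: hydrogen in place of (1-bromoethenyl)carbonyl on a nitrogen on an aromatic ring This difference gives a 4.0-fold higher number from compound 1 to compound 3 (0.60 log units; beyond the scatter). Compound 2 arises from compound 1 by one change: methyl in place of iodo on an aromatic carbon That change produced a 2.2-fold lower number from compound 1 to compound 2 (0.35 log units; beyond the scatter) in this assay. The unmeasured compound 4 `Cc1ccc(C(=O)/C=C/c2ccc(N)cc2)cc1` stands to compound 3 in the same relation: methyl in place of iodo on an aromatic carbon Both place descriptions read identically, so this is the same change. Going by the values given here, the only precedent for this change is the step of a 2.2-fold lower number from compound 1 to compound 2 (0.35 log units; beyond the scatter). Matching that precedent, the expected step is a 2.2-fold lower number from compound 3 to compound 4 (0.34 log units; beyond the scatter). Compound 4 is therefore estimated at 7300 nM, between 3500 nM and 15000 nM.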

Compound 4, half-maximal inhibitory concentration: 31000 nM
Estimate against measurement, compound 4: 4.2-fold (0.63 log units) below, and the stated range ends below it.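

In this assay, methyl in place of iodo does not carry over from one core to the other as a fixed step: the same change on two cores in this assay, a 2.2-fold lower number (0.35 log units; beyond the scatter) from compound 1 to compound 2 and a 1.9-fold higher number (0.29 log units; within the scatter) from compound 3 to compound 4, 4.3-fold (0.63 log units) apart, beyond the scatter of two such steps On the core with the free amine the step, a 1.9-fold higher number from compound 3 to compound 4 (0.29 log units; within the scatter), stays within the scatter, so compound 3 and compound 4 cannot be ordered. Hydrogen in place of (1-bromoethenyl)carbonyl, read with methyl on the ring, gives a 17-fold higher number from compound 2 to compound 4 (1.24 log units; beyond the scatter), so the two changes do not add independently, though these four compounds show neither why nor how widely this holds: the same change on two cores in this assay, a 4.0-fold higher number (0.60 log units; beyond the scatter) from compound 1 to compound 3 and a 17-fold higher number (1.24 log units; beyond the scatter) from compound 2 to compound 4, 4.3-fold (0.63 log units) apart, beyond the scatter of two such steps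

Open, as far as these compounds go, is whether chloro or methoxy in place of iodo would also shift with the core. Also open, from the compounds shown here alone, is how an acetyl group on the nitrogen would compare with (1-bromoethenyl)carbonyl.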